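A few compounds are considered here, and "the series" means these few. Any claim that something is new, unique, unknown or untested is made for them only; others in the source may bear on it.

Working notes on the series.

Compound 1 `CC(Oc1ncnc2ccc(-c3cnn(C4CCNCC4)c3)cc12)c1c(Cl)ccc(F)c1Cl` in a functional assay on SK-BR-3 cells (Homo sapiens) for antiproliferative activity, read by MTT assay, with a stated time of 72 h (on this read-out higher numbers stand for weaker inhibition and lower numbers for stronger inhibition), gives 2500 nM. Compound 3 `CC(Oc1ncnc2ccc(-c3cnn(C)c3)cc12)c1c(Cl)ccc(F)c1Cl` keeps the same core and differs only in the change (methyl in place of piperidin-4-yl on an aromatic nitrogen); in this assay compound 3 gives 27200 nM, so the step of an 11-fold higher number from compound 1 to compound 3 (1.04 log units; beyond the scatter) is the one point of reference in this set for that change.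

Compound 2 `c1cnc2ccc(Nc3ncnc4ccc(-c5cnn(C6CCNCC6)c5)cc34)cc2c1` carries a different core; how the two cores differ is not broken down here. In this assay, for the measured compounds named here, compound 2 gives 2660 nM, a number that sits within the scatter of the one for compound 1, so no order between the two is read from these values.

Compound 4 `Cn1cc(-c2ccc3ncnc(Nc4ccc5ncccc5c4)c3c2)cn1` is not yet measured. It differs from compound 2 by methyl in place of piperidin-4-yl on an aromatic nitrogen, and the place of this change reads the same as for the pair of compound 1 and compound 3, so it is the same change on the other core. Given that the only measured instance of it, the step of an 11-fold higher number from compound 1 to compound 3 (1.04 log units; beyond the scatter), was large and beyond the scatter, the step from compound 2 to compound 4 in this assay is expected to be of similar size, a 9.4-fold higher number from compound 2 to compound 4 (0.97 log units; beyond the scatter), resting on the single precedent and on compound 2 starting at 2660 nM. As far as these compounds go, for compound 4 the estimate in this assay is 25000 nM, with the likely range between 9000 nM and 70000 nM; the transfer to a second core is untested here, so the range is kept wide.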

Compound 4, half-maximal inhibitory concentration: 64 nM
For compound 4 the middle estimate is 390-fold (2.59 log units) above the measured one; the whole stated range lies above it.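

In this assay, methyl in place of piperidin-4-yl on an aromatic nitrogen gives a 42-fold lower number from compound 2 to compound 4 (1.62 log units; beyond the scatter), whereas the same change on the other core gives an 11-fold higher number from compound 1 to compound 3 (1.04 log units; beyond the scatter). The change therefore does not carry from one core to the other in this series, in either direction or size, even though compound 1 and compound 2 stand within the scatter of each other before the change: the same change on two cores in this assay, an 11-fold higher number (1.04 log units; beyond the scatter) from compound 1 to compound 3 and a 42-fold lower number (1.62 log units; beyond the scatter) from compound 2 to compound 4, 450-fold (2.66 log units) apart, beyond the scatter of two such steps This shows that the outcome of the change depends on the core in these two pairs, but with a single pair per core it gives no general rule and does not show which feature of the cores is responsible.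

As far as these compounds go, whether the opposite directions persist with other groups on the same aromatic nitrogen, such as ethyl, a longer chain ending in an amine, or a chain ending in a carboxylic acid, remains open. Also open, from the compounds shown here alone, are which part of the core of compound 2 sets the direction of the step and what the same change would do on a third core.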